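Halogen swap on the benzyl group: compound 3 to compound 4

The source may report more compounds than this note shows. Statements on the series, on what has been measured and on what is new or still open speak of the compounds shown alone.

Compound 1 `OC[C@H]1O[C@@H](n2cnc3c(NCc4ccccc4Br)ncnc32)[C@H](O)[C@@H]1O`: > 166000 nM (a limit)
Compound 2 `COc1cc(CNc2ncnc3c2ncn3[C@@H]2O[C@H](CO)[C@@H](O)[C@H]2O)cc(OC)c1`: "not determined" (no result reported)
Compound 3 `OC[C@H]1O[C@@H](n2cnc3c(NCc4ccc(F)c(F)c4F)ncnc32)[C@H](O)[C@@H]1O`: > 166000 nM (a limit)

All entries refer to a functional assay on HOS cells (Homo sapiens) for antiproliferative activity, with a stated time of 72 h; a higher number here means a weaker inhibitor, a lower number a stronger inhibitor. Compound 3 has no numerical value, only the limit > 166000 nM. The series gives it no rank, since the limit of > 166000 nM in this assay, at which 2 of the 3 values shown sit, and compound 2 has no result.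

The next change leads to compound 4 `OC[C@H]1O[C@@H](n2cnc3c(NCc4ccc(F)c(Cl)c4)ncnc32)[C@H](O)[C@@H]1O`: 3-chloro-4-fluorophenyl in place of 2,3,4-trifluorophenyl on a saturated chain carbon bound to a nitrogen on an aromatic ring. In words, 3-chloro-4-fluorophenyl takes the place of 2,3,4-trifluorophenyl on a saturated chain carbon bound to a nitrogen on an aromatic ring.

For the measured compounds named here, only one measured step bears on this change, as it alters the same place: a step that the two limits leave unreadable from compound 1 to compound 3. It gives neither a size nor a direction. The halogen exchange between compound 1 and compound 3 leaves both compounds at the limit, so the series offers no sign of a change in this assay. No step beyond the scatter is therefore expected, although the data cannot exclude one, and a further limit is the most likely report. The expected size is an at least 1.1-fold lower number from compound 3 to compound 4 (0.04 log units; that floor lies within the scatter). For compound 4 the estimated value is 150000 nM, with an expected range from 40000 nM to 250000 nM.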

Compound 4, half-maximal inhibitory concentration: > 166000 nM
Compound 4 gave a limit, no number; the forecaster's own chance of this, stated with the estimate: 75%; at least 1.1-fold (0.04 log units) between middle value and limit.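

In this assay compound 4 gives > 166000 nM, a limit and not a number. The steps to compound 4 from compound 1 and from compound 3 cannot be read, in size or in direction. The compounds shown leave open whether the halogen pattern on the phenyl ring makes any difference, as the series stays at one limit: the limit of > 166000 nM in this assay, at which 3 of the 4 values shown sit.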